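A few compounds are considered here, and "the series" means these few. Any claim that something is new, unique, unknown or untested is made for them only; others in the source may bear on it.

Compound 1 `CCOC(=O)c1c(NC(=O)CC#N)sc(C(=O)Nc2ccc(Cl)cc2)c1-c1ccccc1` gives 620 nM in this series
Compound 2 `N#CCC(=O)Nc1sc(C(=O)Nc2ccc(Cl)cc2)c(-c2ccccc2)c1C#N` gives 860 nM in this series
Compound 3 `CCOC(=O)c1c(N)sc(C(=O)Nc2ccc(Cl)cc2)c1-c1ccccc1` gives 190 nM in this series

All three numbers come from a functional assay on HT-29 cells (Homo sapiens) for inhibition, read by MTT assay (a higher number here means a weaker inhibitor, a lower number a stronger inhibitor), and the compounds share one core. Compound 1 stands at the upper end of this small set, level with its nearest neighbour: the gap is a 1.4-fold higher number from compound 1 to compound 2 (0.14 log units; within the scatter) and so no real difference can be claimed. Its furthest neighbour is a clearer case, with a 3.3-fold lower number from compound 1 to compound 3 (0.51 log units; beyond the scatter) as the measured step.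

Compound 4 `CCOC(=O)c1c(NC(=O)CC#N)sc(C(=O)Nc2ccccc2)c1-c1ccccc1` has not been measured yet. It differs from compound 1 in one place, hydrogen in place of chloro on an aromatic carbon and in plain words this is hydrogen in place of chloro on an aromatic carbon, turning 4-chlorophenyl into phenyl.

Neither measured step touches the chloro group, so no direct evidence exists for this change. Those steps replace other groups, and they serve only as a guide to how much single changes move the numbers in this series. The larger of them, a 3.3-fold lower number from compound 1 to compound 3 (0.51 log units; beyond the scatter) for the loss of a whole (cyanomethyl)carbonyl group, is only modest. Removing one chlorine is therefore expected to give a small step in this assay and probably none beyond the scatter, with a slight lean towards a higher number. The expected change is a 1.3-fold higher number from compound 1 to compound 4 (0.11 log units; within the scatter) as an estimate only. For compound 4 the estimated value is 800 nM with an expected range from 250 nM to 2200 nM in this assay.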

Compound 4, half-maximal inhibitory concentration: 630 nM
Compound 4: the middle estimate sits 1.3-fold (0.10 log units) above what was measured; the measured number falls inside the stated range.
By their numbers in this assay, from the lowest: compound 3; then compounds 1, 4 and 2 (each within the scatter of the next).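

In this assay, among these compounds, this is the first direct reading at this position, and it gives a 1.0-fold higher number from compound 1 to compound 4 (0.01 log units; within the scatter), so compound 1 and compound 4 cannot be told apart. The earlier steps shown here concerned other parts of the molecule, whereas this one shows that, with everything else held as in compound 1, the chloro group of the 4-chlorophenyl is not needed to keep the number at this level, since a plain phenyl does as well. The data shown offer no explanation of why this swap leaves no measurable mark, and a single pair cannot supply one.

From the compounds shown here alone, only hydrogen and chloro are seen at this place, so it remains open whether a larger or quite different group there, such as a methoxy, a trifluoromethyl, an amine or a carboxylic acid, would also go without effect. Going by these compounds, it is equally open whether the same swap would read the same way on compound 3, which carries a free amino group in place of the (cyanomethyl)carbonyl-bearing nitrogen of compound 1.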